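Cytotoxicity notes: phenyl in place of phenoxy on the core

A few compounds are considered here, and "the series" means these few. Any claim that something is new, unique, unknown or untested is made for them only; others in the source may bear on it.

Measured so far in an ADME assay on HepG2 cells (Homo sapiens) for cytotoxicity, read by luminescence, CellTiter-Glo and ATP content, with a stated time of 72 h; a lower number here means that less compound is needed, a higher number that more compound is needed for the effect:
compound 1 `COc1cccc(CNCCCNc2ccnc3cc(-c4ccc(C(F)(F)F)cc4)ccc23)c1O` — 2210 nM
compound 2 `COc1cccc(CNCCCNc2ccnc3cc(Oc4ccc(C(C)(C)C)cc4)ccc23)c1O` — 1500 nM

For the measured compounds named here, compound 2 carries the lowest of the two numbers in this assay, but its only neighbour is compound 1, and the step of a 1.5-fold lower number from compound 1 to compound 2 (0.17 log units; within the scatter) does not separate the two beyond the scatter.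

Compound 3 `COc1cccc(CNCCCNc2ccnc3cc(-c4ccc(C(C)(C)C)cc4)ccc23)c1O` is next to be measured. Its change from compound 2 is 4-(tert-butyl)phenyl in place of 4-(tert-butyl)phenoxy on an aromatic carbon. Going by the values given here, the one measured step, a 1.5-fold lower number from compound 1 to compound 2 (0.17 log units; within the scatter), changes two things at once, 4-(tert-butyl)phenoxy replacing 4-(trifluoromethyl)phenyl, so it bears only loosely on removing the phenoxy linkage alone; what it does show is no movement beyond the scatter. With nothing else to go on, no step beyond the scatter is expected for compound 3, a 1.2-fold higher number from compound 2 to compound 3 (0.08 log units; within the scatter). Compound 3 is therefore estimated at 1800 nM, with a range from 900 nM to 3600 nM.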

Compound 3, half-maximal effective concentration: 690 nM
The estimate for compound 3 lay 2.6-fold (0.42 log units) above the measured number; measured number outside the range, below it.
By their numbers in this assay, from the lowest: compound 3; then compounds 2 and 1 (each within the scatter of the next).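

For the compounds shown here, removing the phenoxy oxygen matters at this aromatic carbon of the shared core: in this assay, 4-(tert-butyl)phenyl in place of 4-(tert-butyl)phenoxy gives a 2.2-fold lower number from compound 2 to compound 3 (0.34 log units; beyond the scatter), the first step to lie beyond the scatter. The group on the phenyl ring also matters with the direct aryl attachment held constant: tert-butyl in place of trifluoromethyl gives a 3.2-fold lower number from compound 1 to compound 3 (0.51 log units; beyond the scatter), a separate reading that the earlier comparison, with two things changed at once, could not provide.

Still open, on these data alone, is whether the phenoxy-to-phenyl step holds with groups other than tert-butyl, such as trifluoromethyl, an amine or a carboxylic acid on the ring. A methylene or amide link in place of the direct bond is equally unresolved. No supporting measurement bears on why either step occurs.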